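The source may report more compounds than this note shows. Statements on the series, on what has been measured and on what is new or still open speak of the compounds shown alone.

Compound 1 `CC(=O)c1c(Nc2ccc(F)cc2F)[nH]c2c(F)cc(F)cc2c1=O`, compound 2 `CC(=O)c1c(NCc2ccc(F)cc2F)[nH]c2c(F)cc(F)cc2c1=O` and compound 3 `CC(=O)c1c(NCc2ccc(F)cc2)[nH]c2c(F)cc(F)cc2c1=O` were tested in an ADME assay on Vero cells (Chlorocebus sabaeus) for cytotoxicity; on this read-out higher numbers stand for lower toxicity in this test and lower numbers for higher toxicity in this test. In this assay compound 1 gives > 25000 nM, which is a limit of the assay rather than a number. Compound 2 gives > 25000 nM, likewise a limit. Compound 3 gives > 25000 nM, again a limit. Accordingly, a step that the two limits leave unreadable from compound 3 to compound 2 and a step that the two limits leave unreadable from compound 1 to compound 3, since (the limit of > 25000 nM in this assay, at which 3 of the 3 values shown sit). Compound 4 `CC(=O)c1c(Nc2ccc(F)c(F)c2F)[nH]c2c(F)cc(F)cc2c1=O` has not yet been measured. It differs from compound 1 by fluoro in place of hydrogen on an aromatic carbon. The same kind of change, (fluoro in place of hydrogen on an aromatic carbon), occurs from compound 3 to compound 2, though there the place is ortho to a large group and meta to a fluoro group, whereas in compound 4 it is ortho to two fluoro groups and meta to a large group. The two cores differ by 2,4-difluorophenyl in place of 4-fluorobenzyl on a nitrogen on an aromatic ring. In this assay a step that the limit leaves unreadable from compound 1 to compound 4 is expected, resting on (the limit of > 25000 nM in this assay, at which 3 of the 3 values shown sit). Compound 4 is estimated at 30000 nM, between 15000 nM and 90000 nM.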

Compound 4, half-maximal cytotoxic concentration: > 25000 nM
Compound 4: a limit, no number; the forecaster's own chance of this, stated with the estimate: 85%; the middle value is on the limit's open side.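

In this assay, going by these compounds alone, compound 1 and compound 4 both sit at a limit of the assay rather than a number, so no step between them can be read. The compounds shown leave open at what concentration any of them would become toxic to these cells, and whether the added fluoro changes that.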